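Chloro for methyl on the anilide ring of compound 2

The source may report more compounds than this note shows. Statements on the series, on what has been measured and on what is new or still open speak of the compounds shown alone.

Of the compounds shown here, three of the shared core have been measured in a functional assay on Huh-7 cells (Homo sapiens) for inhibition, read by MTT assay, with a stated time of 48 h; on this read-out higher numbers stand for weaker inhibition and lower numbers for stronger inhibition. Compound 1 `O=C(/C=C/c1coc2cc(O)ccc2c1=O)NCc1ccc(F)cc1` gives > 100000 nM, which is a limit of the assay rather than a number. Compound 2 `COc1ccc2c(=O)c(/C=C/C(=O)Nc3ccc(C)cc3)coc2c1` likewise gives > 100000 nM, again only a limit. Compound 3 `COc1ccc2c(=O)c(/C=C/C(=O)Nc3cc(C)ccc3C)coc2c1` gives 11100 nM. Going by the values given here, the single measured step between neighbours, an at least 9.0-fold lower number from compound 2 to compound 3 (0.95 log units; beyond the scatter), is the only change of the anilide ring on record, and it moves the number away from the limit of > 100000 nM in this assay, at which 2 of the 3 values shown sit, into the measurable range. Compound 2 thus stands at that limit, alongside compound 1.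

Compound 4 `COc1ccc2c(=O)c(/C=C/C(=O)Nc3ccc(Cl)cc3)coc2c1` differs from compound 2 by chloro in place of methyl on an aromatic carbon. Among the compounds with values here, no measured step concerns a chloro for methyl exchange, and the step from compound 2 to compound 3 involves a different methyl pattern, so it offers only weak guidance here. Compound 4 is therefore expected to remain near where compound 2 sits, with an at least 1.1-fold lower number from compound 2 to compound 4 (0.04 log units; that floor lies within the scatter) anticipated as no step beyond the scatter, and a fair chance that this assay again reports only a limit. For compound 4 the estimated value in this assay is 90000 nM, within 15000 nM to 400000 nM.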

Compound 4, half-maximal inhibitory concentration: 37100 nM
Beside the measured number, compound 4's estimate is 2.4-fold (0.38 log units) above it; measured number inside the range.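

In this assay, chloro in place of methyl on an aromatic carbon, para to a large group, gives an at least 2.6-fold lower number from compound 2 to compound 4 (0.43 log units; beyond the scatter) and so brings the number into the measurable range through a change of one heavy atom. This step is only a floor, because compound 2 gives a limit and not a number: the limit of > 100000 nM in this assay, at which 2 of the 4 values shown sit. The exchange does not match the 2,5-dimethylphenyl pattern, since the record shows a 3.3-fold higher number from compound 3 to compound 4 (0.52 log units; beyond the scatter) and compound 3 therefore remains the stronger of these two.

On these data alone, whether this gain belongs to chloro itself remains open, as does whether fluoro, bromo, methoxy or trifluoromethyl at the same place would give a lower number still. As far as these compounds go, it is also open whether chloro could be combined with a second group on the ring to go beyond compound 3.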